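The source may hold more compounds than are shown below. What is called first, only, known or untested is meant among the compounds shown, and "the series" means these compounds.

Compound 1 `CC1(C)C=C(n2ccccc2=O)c2cc(C(=O)c3ccccc3)ccc2O1` carries a benzoyl group on the shared core, and in a functional assay (aorta) with Rattus norvegicus as the target (on this read-out lower numbers stand for lower potency and higher numbers for higher potency (the scale is a negative logarithm)), compound 1 gives 6.61. Compound 2 `CC1(C)C=C(n2ccccc2=O)c2cc(C(=O)c3ccccc3F)ccc2O1` differs from it by fluoro in place of hydrogen on an aromatic carbon and in this assay compound 2 gives 7.08, so the change made a number 0.47 log units higher from compound 1 to compound 2 (beyond the scatter). Compound 3 `CC1(C)C=C(n2ccccc2=O)c2cc(OC(=O)Nc3ccccc3)ccc2O1` carries a phenylcarbamoyl group instead; the difference between the two cores is not broken down here. In this assay compound 3 gives 5.3, the lowest of the three. Compound 4 `CC1(C)C=C(n2ccccc2=O)c2cc(OC(=O)Nc3ccccc3F)ccc2O1` is compound 3 with fluoro in place of hydrogen on an aromatic carbon, the same change at the same kind of place. Because that change gave a number 0.47 log units higher from compound 1 to compound 2 (beyond the scatter) once, a step of similar size is expected here, namely a number 0.40 log units higher from compound 3 to compound 4 (beyond the scatter). Compound 4 is therefore estimated at 5.7, probably between 5.2 and 6.3.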

Compound 4, logarithm of the reciprocal of the active concentration, log(1/C): 5.38
Compound 4: middle estimate off by 0.32 log units, on the high side, within the range that was stated.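

With the phenylcarbamoyl group on the shared core, fluoro in place of hydrogen gives a number 0.08 log units higher from compound 3 to compound 4 (within the scatter) in this assay, so on this core the change has no effect that can be told from scatter. Set beside the step on the benzoyl core, the two results cannot be called different: the same change on two cores in this assay, a number 0.47 log units higher (beyond the scatter) from compound 1 to compound 2 and a number 0.08 log units higher (within the scatter) from compound 3 to compound 4, 0.39 log units apart, within the scatter of two such steps The pairs therefore do not show that the rise seen with the benzoyl group carries over to the phenylcarbamoyl group, nor that it is lost, and one pair per core cannot settle whether the core matters.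

As far as these compounds go, what chloro, methyl or an amine in place of that hydrogen would do on either core stays open. So does the size of the fluoro step on any third core.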